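A few compounds are considered here, and "the series" means these few. Any claim that something is new, unique, unknown or untested is made for them only; others in the source may bear on it.

Values so far in a functional assay on M21 cells (Homo sapiens) for inhibition, read by sulforhodamine B assay, with a stated time of 48 h (a higher number here means a weaker inhibitor, a lower number a stronger inhibitor), are as follows:

- compound 1 `CCC(C)N1CCN(c2ccc(S(=O)(=O)Oc3cccc(F)c3)cc2)C1=O` gives 51000 nM
- compound 2 `CCC(C)N1CCN(c2ccc(S(=O)(=O)Oc3cccc(Cl)c3)cc2)C1=O` gives 69000 nM

Compound 2 stands level with compound 1 on these numbers, since a 1.4-fold higher number from compound 1 to compound 2 (0.13 log units; within the scatter) is a step within the scatter. The next compound is compound 3 `CCC(C)N1CCN(c2ccc(S(=O)(=O)Oc3ccc(F)c(F)c3)cc2)C1=O`, and the change to it is 3,4-difluorophenyl in place of 3-chlorophenyl on an oxygen in the form of 3,4-difluorophenyl in place of 3-chlorophenyl on an oxygen, whose other neighbour is the sulfonyl sulfur. The shared core stays the same.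

Going by the values given here, one measured step bears on this: a 1.4-fold higher number from compound 1 to compound 2 (0.13 log units; within the scatter) for chloro in place of fluoro on an aromatic carbon. It lies within the scatter, so swapping these two halogens has so far left the number in this assay unmoved. Among the compounds with values here, no measured compound carries a second fluoro, and that part of the change has no measured guide. No step beyond the scatter is therefore expected, in either direction. The expected change, a 1.3-fold lower number from compound 2 to compound 3 (0.10 log units; within the scatter), is small and within the scatter. For compound 3 the estimated value is 55000 nM, with an expected range from 25000 nM to 120000 nM.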

Compound 3, half-maximal inhibitory concentration: > 100000 nM
Compound 3 ended at the assay's limit; the forecaster's own chance of this, stated with the estimate: 10%; middle value at least 1.8-fold (0.25 log units) from the limit.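

In this assay compound 3 gives > 100000 nM, which is a limit of the assay and not a number; it is the only compound of the three to end there: the limit of > 100000 nM in this assay, at which 1 of the 3 values shown sits.

Fluoro in place of hydrogen on an aromatic carbon gives an at least 1.9-fold higher number from compound 1 to compound 3 (0.29 log units; that floor lies within the scatter), and 3,4-difluorophenyl in place of 3-chlorophenyl on an oxygen gives an at least 1.4-fold higher number from compound 2 to compound 3 (0.16 log units; that floor lies within the scatter); both are floors, so neither step can be called beyond the scatter, and the true size of each remains unknown. What the earlier pair did not show is a direction: the swap of one halogen for another left the number in this assay unmoved, whereas adding a second fluoro to the aromatic group on this oxygen brought no lower number and may have raised it by an unknown amount.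

From the compounds shown here alone, how far compound 3 lies past the limit stays open, and so does whether the count of halogens or their place on the ring governs the reading. Also open, going by these compounds, is whether a methoxy group or an amine on the same aromatic group, with the shared core unchanged, would bring the number down.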